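Meta acetyl on the phenyl urea of compound 2

This account rests on a few compounds, and the source may have more. Where it says the series, first, only, none or still open, it means among the compounds named here.

Compound 2 `N#CC1CN1C(=O)Nc1ccccc1` is the parent aryl urea of this small set. In a functional assay on WiDr cells (Homo sapiens) for inhibition (on this read-out lower numbers stand for stronger inhibition and higher numbers for weaker inhibition), compound 2 gives 5000 nM, the highest of the two plain numbers available; compound 1 `CCOC(=O)c1ccc(NC(=O)N2CC2C#N)cc1` gives 2500 nM, and the step of a 2.0-fold higher number from compound 1 to compound 2 (0.30 log units; within the scatter) lies within the scatter. Compound 3 `N#CC1CN1C(=O)Nc1ccc(S(N)(=O)=O)cc1` carries a sulfamoyl group on the ring, and in this assay compound 3 reaches only the limit > 38000 nM, which is a limit rather than a number. The step of an at least 7.6-fold higher number from compound 2 to compound 3 (0.88 log units; beyond the scatter) is a clear loss, and it rests on (the limit of > 38000 nM in this assay, at which 1 of the 3 values shown sits).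

Compound 4 `CC(=O)c1cccc(NC(=O)N2CC2C#N)c1` differs from compound 2 by the change (acetyl in place of hydrogen on an aromatic carbon). The two measured steps pull in different directions: the ethoxycarbonyl group left potency essentially unchanged, while the sulfamoyl group erased it. The acetyl group enters at a different ring position from either, so the measured steps bear on it only loosely. Compound 4 is therefore expected to sit near compound 2, with a 1.3-fold lower number from compound 2 to compound 4 (0.10 log units; within the scatter) as a change no larger than the scatter, and its estimated value is 4000 nM (range 1500 nM to 15000 nM).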

Compound 4, half-maximal inhibitory concentration: 3300 nM
Compound 4: the middle estimate sits 1.2-fold (0.08 log units) above what was measured; measured number inside the range.
By their numbers in this assay, from the lowest: compounds 1, 4 and 2 (each within the scatter of the next). At a limit, above all of these: compound 3.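

In this assay, acetyl on the aromatic carbon meta to a group of 8 heavy atoms gives a 1.5-fold lower number from compound 2 to compound 4 (0.18 log units; within the scatter), so this change stays within the scatter. Compound 4 is the only compound shown with a group at this ring position, and it shows that the position accepts acetyl, with its 3 heavy atoms and 1 hydrogen-bond acceptor, without a change beyond the scatter. The compounds shown offer no measurement that explains this result.

As far as these compounds go, one group at this position says little about others, so it remains open whether an amine, a carboxylic acid or a longer chain there would also stay within the scatter of compound 2. From the compounds shown here alone, it also remains open whether sulfamoyl at this position would bring the same loss that it brings at its ring position in compound 3.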